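This account rests on a few compounds, and the source may have more. Where it says the series, first, only, none or still open, it means among the compounds named here.

Compound 1 `COc1ccccc1-c1ccc2ncn(-c3cc(OC)c(OC)c(OC)c3)c2c1` carries a 2-methoxyphenyl on the shared core. For the measured compounds named here, in a functional assay on MCF7 cells (Homo sapiens) for antiproliferative activity, read by MTT assay, with a stated time of 72 h (on this read-out lower numbers stand for stronger inhibition and higher numbers for weaker inhibition), compound 1 gives 1750 nM, the only full number in the set. Compound 2 `COc1cc(-n2cnc3ccc(-c4ccccc4Cl)cc32)cc(OC)c1OC` has chloro in place of methoxy on that aromatic carbon. In this assay compound 2 reaches only a limit of the assay, > 10000 nM. The step of an at least 5.7-fold higher number from compound 1 to compound 2 (0.75 log units; beyond the scatter) therefore rests on (the limit of > 10000 nM in this assay, at which 1 of the 2 values shown sits), so its true size is open beyond being at least modest. Compound 3 `COc1cc(-n2cnc3ccc(-c4cccc(C)c4)cc32)cc(OC)c1OC` is the next entry: 3-methylphenyl in place of 2-methoxyphenyl on an aromatic carbon. Going by the values given here, only the step from compound 1 to compound 2 bears on this change, and it points one way: replacing the methoxy on the pendant ring, whether by chloro or by the move to 3-methylphenyl, removes the single hydrogen-bond acceptor counted in the change. The expectation is a loss of potency, a clear rise in the number, though methyl need not behave like chloro. Compound 3 is expected to give 4500 nM, within 1500 nM to 14000 nM, a step of a 2.6-fold higher number from compound 1 to compound 3 (0.41 log units; beyond the scatter). A limit rather than a number is a real possibility for compound 3.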

Compound 3, half-maximal inhibitory concentration: 360 nM
The estimate for compound 3 lay 13-fold (1.10 log units) above the measured number; measured number below the stated range.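

In this assay, the swap gives a 4.9-fold lower number from compound 1 to compound 3 (0.69 log units; beyond the scatter), so on this aromatic carbon of the shared core, the hydrogen-bond acceptor counted in 2-methoxyphenyl is not needed for activity among the compounds shown; 3-methylphenyl has none and still gives the lower number. Compound 2 had suggested that replacing the methoxy costs activity, but compound 3 goes against any rule that losing the methoxy means losing potency. The step of an at least 27-fold lower number from compound 2 to compound 3 (1.44 log units; beyond the scatter) shows that the pendant ring's substitution can move the result strongly in either direction, though this size is only a bound, since compound 2 stands at a limit of the assay: the limit of > 10000 nM in this assay, at which 1 of the 3 values shown sits.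

Compound 3 differs from compound 1 in both the substituent and where it sits on the pendant ring, so the compounds shown do not separate these two contributions. That would take methoxy or chloro where the methyl of compound 3 sits and methyl where the methoxy of compound 1 sits, while an amine or a carboxylic acid at the same place would test whether anything beyond a small neutral group is accepted.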